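Methyl on the Five-Membered Ring: Potency in Mice

A few compounds are considered here, and "the series" means these few. Any claim that something is new, unique, unknown or untested is made for them only; others in the source may bear on it.

Measured compounds:
compound 1 `CC1CCC(=O)N1CC#CCn1ccnc1`: 1.1 mg/kg
compound 2 `Cc1cncn1CC#CCN1C(=O)CCC1C`: 1.4 mg/kg
compound 3 `CC(=O)N(C)CC#CCn1ccnc1`: > 100 mg/kg

In a functional assay on the whole organism for antagonist activity, with Mus musculus as the target (on this read-out higher numbers stand for an effect only at larger amounts of compound and lower numbers for an effect already at smaller amounts), compound 1 gives 1.1 mg/kg and compound 2 gives 1.4 mg/kg. The change between them is methyl in place of hydrogen on an aromatic carbon, and it made a step of a 1.3-fold higher number from compound 1 to compound 2 (0.10 log units; within the scatter). For compound 3 the value in this assay is only a limit, > 100 mg/kg. That limit is the limit of > 100 mg/kg in this assay, at which 1 of the 3 values shown sits. The difference between the core of compound 1 and the core of compound 3 is not broken down here.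

Compound 4 `CC(=O)N(C)CC#CCn1cncc1C` has not yet been measured in this assay. It differs from compound 3 by methyl in place of hydrogen on an aromatic carbon, the same kind of change as that from compound 1 to compound 2; the surroundings differ only in that the ring atom bears a group of 9 heavy atoms in one case and a large group in the other. Since the step of a 1.3-fold higher number from compound 1 to compound 2 (0.10 log units; within the scatter) was small, the step that the limit leaves unreadable from compound 3 to compound 4 is expected to be of similar size. Compound 4 is therefore estimated at 150 mg/kg, between 50 mg/kg and 500 mg/kg, and most likely again reported only as a limit.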

Compound 4, dose for half-maximal effect: > 100 mg/kg
Compound 4 ended at the assay's limit; the forecaster's own chance of this, stated with the estimate: 80%; the middle value is on the limit's open side.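

Compound 3 and compound 4 are both reported only as limits in this assay, so the step between them cannot be read: the limit of > 100 mg/kg in this assay, at which 2 of the 4 values shown sit.
Going by these compounds, what methyl in place of hydrogen does on the core of compound 3 remains open.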